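Trifluoromethyl in place of hydrogen on compound 1

A few compounds are considered here, and "the series" means these few. Any claim that something is new, unique, unknown or untested is made for them only; others in the source may bear on it.

Going by the values given here, in a physicochemical assay, read by spectrophotometry, with a stated time of 25 min (on this read-out higher numbers stand for weaker inhibition and lower numbers for stronger inhibition), compound 1 (`O=c1cc(-c2ccccc2)oc2cc(OCCCCNc3nc4ccccc4s3)cc(O)c12`) gives 26.5 ug/mL and compound 2 (`Cc1ccc2nc(NCCCCOc3cc(O)c4c(=O)cc(-c5ccccc5)oc4c3)sc2c1`) gives 28.1 ug/mL so the two numbers measured so far lie within the scatter of each other and neither compound stands apart. Compound 3 (`O=c1cc(-c2ccccc2)oc2cc(OCCCCNc3nc4ccc(C(F)(F)F)cc4s3)cc(O)c12`) has not yet been measured. Compared with compound 1, it differs by trifluoromethyl in place of hydrogen on an aromatic carbon with trifluoromethyl in place of hydrogen on an aromatic carbon and the rest of the structure unchanged. Among the compounds with values here, only one measured step bears on this change: methyl in place of hydrogen on an aromatic carbon, which gives a 1.1-fold higher number from compound 1 to compound 2 (0.03 log units; within the scatter) and leaves the number within the scatter. Within the data shown here, that is a single precedent, and no measured compound carries trifluoromethyl, so the expectation is loose. No step beyond the scatter is expected in this assay and no direction can be argued with any confidence. The estimated step is a 1.1-fold higher number from compound 1 to compound 3 (0.02 log units; within the scatter) and it is expected to stay within the scatter. For compound 3 the expected value is 28 ug/mL (estimated range 15 ug/mL to 50 ug/mL).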

Compound 3, half-maximal inhibitory concentration: 16.3 ug/mL
Compound 3: middle estimate off by 1.7-fold (0.23 log units), on the high side; the range from low to high includes it.
By their numbers in this assay, from the lowest: compounds 3, 1 and 2 (each within the scatter of the next).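

In this assay, trifluoromethyl in place of hydrogen on an aromatic carbon, on the six-membered aromatic ring of carbon only, gives a 1.6-fold lower number from compound 1 to compound 3 (0.21 log units; within the scatter), so this place takes a group of 4 heavy atoms, not only the methyl of compound 2, with no step beyond the scatter. Exchanging that methyl for trifluoromethyl at the same place gives a 1.7-fold lower number from compound 2 to compound 3 (0.24 log units; within the scatter), so compound 1, compound 2 and compound 3 cannot be separated on this read-out, and hydrogen, methyl and trifluoromethyl at this place are not shown to differ, although both new steps are larger than the earlier methyl step and all of them remain within the scatter. No measurement presented here offers an explanation for these numbers.

The three compounds leave open whether any group at this place can move the number beyond the scatter, for instance an amine, a carboxylic acid or a nitrile, none of which appears among them. They also leave open how much the number depends on parts of the structure that all three share, such as the hydroxyl on the core or the chain linking the two ring systems, which a longer chain would test.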